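The source may report more compounds than this note shows. Statements on the series, on what has been measured and on what is new or still open speak of the compounds shown alone.

Compound 1 `CC(C)(C)n1ncc(OCc2nnc(-c3ccccc3F)o2)c(Cl)c1=O` is the starting point of this comparison. In a physicochemical assay for lipophilicity (on this read-out lower numbers stand for lower lipophilicity and higher numbers for higher lipophilicity), compound 1 gives 2.89, the lowest of the three numbers at hand. Its nearest neighbour is compound 3 `CC(C)(C)n1ncc(OCc2nnc(-c3ccccc3Cl)o2)c(Cl)c1=O`, which in this assay gives 3.19, so that a number 0.30 log units higher from compound 1 to compound 3 (within the scatter). The furthest is compound 2 `CCc1ccc(-c2nnc(COc3cnn(C(C)(C)C)c(=O)c3Cl)o2)cc1`, which in this assay gives 3.52, with a number 0.63 log units higher from compound 1 to compound 2 (beyond the scatter). Between those two, a number 0.33 log units lower from compound 2 to compound 3 (beyond the scatter).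

Compound 4 `COc1ccc(-c2nnc(COc3cnn(C(C)(C)C)c(=O)c3Cl)o2)cc1` has not been measured. It differs from compound 1 in one place: 4-methoxyphenyl in place of 2-fluorophenyl on an aromatic carbon. Within the data shown here, no measured step introduces a methoxy group, so no step bears directly on this change. Among the measured compounds shown here, the only guidance is that the 4-ethylphenyl of compound 2 raised the number modestly over the 2-fluorophenyl of compound 1, while the halogen swap between compound 1 and compound 3 stayed within the scatter. A 4-methoxyphenyl brings one hydrogen-bond acceptor where the 2-fluorophenyl had none, and the expectation is therefore a step in this assay that is either small or not beyond the scatter, if anything downward. Compound 4 is estimated at 2.75, within 2.4 to 3.1, which would mean a number 0.14 log units lower from compound 1 to compound 4 (within the scatter).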

Compound 4, partition coefficient: 3.52
Beside the measured number, compound 4's estimate is 0.77 log units below it, and the stated range ends below it.
By their numbers in this assay, from the lowest: compounds 1 and 3 (each within the scatter of the next); then compounds 2 and 4 (each within the scatter of the next).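

In this assay, the 4-methoxyphenyl on this carbon of the five-membered aromatic ring groups with the 4-ethylphenyl and not with the two halogenated phenyls: there is no change at the digits printed from compound 2 to compound 4 (within the scatter), set against a number 0.63 log units higher from compound 1 to compound 4 (beyond the scatter) and a number 0.33 log units higher from compound 3 to compound 4 (beyond the scatter). Among these four compounds, then, 4-ethylphenyl and 4-methoxyphenyl both stand above 2-fluorophenyl and 2-chlorophenyl, no compound goes against this, and the hydrogen-bond acceptor that enters with the methoxy group does not separate compound 4 from compound 2. Nothing available explains why the methoxy and ethyl compounds fall together.

The compounds shown leave open whether the higher numbers follow the place of the group on the phenyl ring or the loss of the halogen, since each step to compound 4 changes both at once, and a 4-chlorophenyl or a 2-methoxyphenyl would help to separate the two. They also leave open whether the same level would hold for a phenyl ring carrying an amine or a carboxylic acid.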